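The compounds below may be only part of what the source reports. "The series", "measured", "known", "first", "only" and "open" are said of these compounds alone.

Three compounds share one core and differ only in the aromatic ring attached to it. Compound 1 `CCc1ccc(Nc2nccc(-c3cnccn3)n2)cc1` gives 1900 nM in a functional assay for inhibition, with Homo sapiens as the target; a higher number here means a weaker inhibitor, a lower number a stronger inhibitor. Compound 2 `CCc1ccc(Nc2nccc(-c3ccncc3)n2)cc1` gives 7700 nM in this assay, and compound 3 `CCc1ccc(Nc2nccc(-c3ccccn3)n2)cc1` gives 2100 nM. Among these three numbers compound 3 stands second highest: the step of a 1.1-fold higher number from compound 1 to compound 3 (0.04 log units; within the scatter) lies within the scatter, while a 3.7-fold lower number from compound 2 to compound 3 (0.56 log units; beyond the scatter) and a 4.1-fold higher number from compound 1 to compound 2 (0.61 log units; beyond the scatter) lie beyond it. Compound 4 `CC(=O)N(C)c1ccc(Nc2nccc(-c3ccccn3)n2)cc1` keeps the ring of compound 3 and alters the other end of the molecule instead: acetyl(methyl)amino in place of ethyl on an aromatic carbon. Among the measured compounds shown here, none of the measured steps touches this position; all three concern the ring that varies among the first three compounds, so they offer no direct guide to the size or direction of this change. For the measured compounds named here, with no precedent in the data, compound 4 is expected to show a step of a 1.2-fold higher number from compound 3 to compound 4 (0.08 log units; within the scatter), with wide uncertainty. The estimate for compound 4 in this assay is 2500 nM, within a range from 600 nM to 10000 nM.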

Compound 4, half-maximal inhibitory concentration: 1800 nM
Compound 4: the middle estimate sits 1.4-fold (0.14 log units) above what was measured, within the range that was stated.
By their numbers in this assay, from the lowest: compounds 4, 1 and 3 (each within the scatter of the next); then compound 2.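

In this assay, acetyl(methyl)amino in place of ethyl gives a 1.2-fold lower number from compound 3 to compound 4 (0.07 log units; within the scatter), so at this position, para to a large group, 5 heavy atoms and 1 hydrogen-bond acceptor can replace 2 heavy atoms and no acceptor without a change beyond the scatter. Among the compounds shown here, the earlier compounds showed only that the number can respond to the attached aromatic ring, as in a 3.7-fold lower number from compound 2 to compound 3 (0.56 log units; beyond the scatter); this is the first sign that the other end of the molecule can carry a quite different group with no such response. The data offer no measurement that bears on why the number holds steady here.

From the compounds shown here alone, it remains open whether an amine, a carboxylic acid or a longer chain at this position would also leave the number within the scatter. Going by these compounds, it is equally open whether acetyl(methyl)amino would behave the same way with pyridin-4-yl or pyrazin-2-yl as the attached ring.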